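Methyl in Place of Chloro on the Sulfonyl Aryl Ring

This account rests on a few compounds, and the source may have more. Where it says the series, first, only, none or still open, it means among the compounds named here.

Measured compounds:
Compound 1 `O=C(Cc1ccc(F)cc1)NS(=O)(=O)c1ccc(Cl)cc1`: 6.28 ug/mL
Compound 2 `Cc1ncc([N+](=O)[O-])n1CC(=O)NS(=O)(=O)c1ccc(Br)cc1`: 3.03 ug/mL

In a functional assay on A549 cells (Homo sapiens) for antiproliferative activity, read by MTT assay, with a stated time of 48 h (a higher number here means a weaker inhibitor, a lower number a stronger inhibitor), compound 1 gives 6.28 ug/mL, the highest of the two numbers shown. Compound 2 gives 3.03 ug/mL, a lower number beyond the usual scatter. Compound 3 `Cc1ccc(S(=O)(=O)NC(=O)Cc2ccc(F)cc2)cc1` differs from compound 1 by methyl in place of chloro on an aromatic carbon. Among the compounds with values here, no pair of measured compounds covers this change, so nothing measured tells its size. The step is expected to be small, estimated at a 1.3-fold higher number from compound 1 to compound 3 (0.11 log units; within the scatter), within or barely beyond the scatter and, if anything, toward a higher number. Compound 3 is therefore expected to give about 8 ug/mL, in a range from 4 ug/mL to 16 ug/mL.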

Compound 3, half-maximal inhibitory concentration: 12 ug/mL
Compound 3: middle estimate off by 1.5-fold (0.18 log units), on the low side, and the stated range covers the measured number.
By their numbers in this assay, from the lowest: compound 2; then compounds 1 and 3 (each within the scatter of the next).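

In this assay, within the data shown here, the change from 4-chlorophenyl to 4-methylphenyl gives a 1.9-fold higher number from compound 1 to compound 3 (0.28 log units; within the scatter) and is the first step measured at this position. It shows that, on the core of compound 1, methyl can stand in place of chloro without a change beyond the scatter. Nothing at hand gives a cause for the size of this step.

The compounds shown leave open whether an amine or a carboxylic acid at this place would move the number beyond the scatter. They also leave open whether methyl in place of halogen would read the same on the core of compound 2.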